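The compounds below may be only part of what the source reports. "The series", "measured", "known", "first", "only" and "open" are said of these compounds alone.

Compound 3 `N#Cc1cccc(COc2ccc(-c3cc(CN4CCN(Cc5ccc(C(F)(F)F)cc5)CC4)no3)cc2)c1` and compound 4 `Cc1cc(-c2cc(CN3CCN(Cc4ccc(C(F)(F)F)cc4)CC3)no2)ccc1OCc1cccc(C#N)c1` differ in one place: methyl in place of hydrogen on an aromatic carbon. In a functional assay on MCF7 cells (Homo sapiens) for antiproliferative activity, read by sulforhodamine B assay, with a stated time of 72 h (a lower number here means a stronger inhibitor, a higher number a weaker inhibitor), compound 3 gives 800 nM. The same kind of change links compound 1 `FC(F)(F)c1ccc(CN2CCN(Cc3cc(-c4ccc(OCc5ccccc5)cc4)on3)CC2)cc1` to compound 2 `Cc1ccccc1COc1ccc(-c2cc(CN3CCN(Cc4ccc(C(F)(F)F)cc4)CC3)no2)cc1`, where (methyl in place of hydrogen on an aromatic carbon); there the place is ortho to a large group, whereas in compound 4 the methyl sits ortho to a (3-cyanobenzyl)oxy group and meta to a large group. In this assay compound 1 gives 2900 nM and compound 2 gives 3700 nM, so a 1.3-fold higher number from compound 1 to compound 2 (0.11 log units; within the scatter). The cores of compound 1 and compound 3 differ as cyano in place of hydrogen on an aromatic carbon, with a 3.6-fold lower number from compound 1 to compound 3 (0.56 log units; beyond the scatter), and a 4.6-fold lower number from compound 2 to compound 3 (0.67 log units; beyond the scatter). Compound 4 is expected to show a 1.3-fold higher number from compound 3 to compound 4 (0.10 log units; within the scatter) because a 1.3-fold higher number from compound 1 to compound 2 (0.11 log units; within the scatter). Compound 4 is therefore estimated at 1000 nM, between 500 nM and 2200 nM.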

Compound 4, half-maximal inhibitory concentration: 700 nM
Estimate against measurement, compound 4: 1.4-fold (0.15 log units) above, and the stated range covers the measured number.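

In this assay, the added methyl gives a 1.1-fold lower number from compound 3 to compound 4 (0.06 log units; within the scatter). Set beside the same change on the other core, the two steps agree: the same change on two cores in this assay, a 1.3-fold higher number (0.11 log units; within the scatter) from compound 1 to compound 2 and a 1.1-fold lower number (0.06 log units; within the scatter) from compound 3 to compound 4, 1.5-fold (0.16 log units) apart, within the scatter of two such steps. So on these two cores the methyl step stays within the scatter both times, but the methyl stands at a different place in each pair, and two pairs do not make a rule for other places or other cores in this series.

The compounds shown leave open what an ethyl, a methoxy or a chlorine would give in place of the methyl, ortho to a (3-cyanobenzyl)oxy group. They also leave open what a methyl at the matching place would give on the core of compound 1, which has no nitrile.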